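Working notes: from compound 3 to compound 4

The compounds below may be only part of what the source reports. "The series", "measured", "known", "first", "only" and "open" are said of these compounds alone.

Values in a functional assay on NCI-H522 cells (Homo sapiens) for inhibition, read by sulforhodamine B assay, with a stated time of 48 h; on this read-out lower numbers stand for stronger inhibition of growth and higher numbers for weaker inhibition of growth:
- compound 1 `O=C(Cc1csc2nc(-c3ccc(Br)cc3)cn12)N/N=C/c1ccccc1`: 60300 nM
- compound 2 `O=C(Cc1csc2nc(-c3ccc(Br)cc3)cn12)N/N=C/c1ccccc1O`: 26900 nM
- compound 3 `O=C(Cc1csc2nc(-c3ccc(Br)cc3)cn12)N/N=C/c1ccc(O)cc1`: 34700 nM

Compound 3 sits in the middle of the three numbers, within the scatter of both compound 1 and compound 2. The next structure, compound 4 `COc1cccc(OC)c1/C=N/NC(=O)Cc1csc2nc(-c3ccc(Br)cc3)cn12`, differs from it as follows: 2,6-dimethoxyphenyl in place of 4-hydroxyphenyl on a carbon with a double bond to nitrogen. Among the compounds with values here, three measured steps bear on this aryl group, and all are small: a 2.2-fold lower number from compound 1 to compound 2 (0.35 log units; beyond the scatter), a 1.7-fold lower number from compound 1 to compound 3 (0.24 log units; within the scatter) and a 1.3-fold higher number from compound 2 to compound 3 (0.11 log units; within the scatter). Within the data shown here, compound 4 has no hydroxy group, and the one measured compound without it, compound 1, gives 60300 nM. A small move towards that number is therefore expected in this assay. The expected change is a 1.3-fold higher number from compound 3 to compound 4 (0.11 log units; within the scatter). Compound 4 is estimated at 45000 nM, with an expected range of 20000 nM to 100000 nM.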

Compound 4, concentration for total growth inhibition: > 100000 nM
Compound 4 gave a limit, no number; the forecaster's own chance of this, stated with the estimate: 15%; middle value at least 2.2-fold (0.34 log units) away from the limit.
By their numbers in this assay, from the lowest: compounds 2, 3 and 1 (each within the scatter of the next, the first and the last beyond it). At a limit, above all of these: compound 4.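

In this assay compound 4 gives > 100000 nM, a limit and not a number: the limit of > 100000 nM in this assay, at which 1 of the 4 values shown sits.

At this position on a carbon with a double bond to nitrogen, 2,6-dimethoxyphenyl separates clearly from both hydroxyphenyl groups, with an at least 2.8-fold higher number from compound 3 to compound 4 (0.45 log units; beyond the scatter) and an at least 3.7-fold higher number from compound 2 to compound 4 (0.57 log units; beyond the scatter). Against phenyl, an at least 1.6-fold higher number from compound 1 to compound 4 (0.21 log units; that floor lies within the scatter) leaves no order that can be stated.

Going by these compounds, whether a single methoxy group on this ring gives the same shift remains open. On these data alone, the outcome with an amine or a carboxylic acid on the ring also remains open.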